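A few compounds are considered here, and "the series" means these few. Any claim that something is new, unique, unknown or untested is made for them only; others in the source may bear on it.

Compound 1 `CC(C)(C)Cc1c(-c2ccccc2)sc(N)c1C(=O)c1ccc(Cl)cc1` is measured in an assay on CHO cells for displacement of a labelled ligand from adenosine receptor A1 (Homo sapiens), read by scintillation counting, tested at 10 uM (a lower number here means less inhibition, a higher number more inhibition at the concentration tested (going by the name of the read-out)), where compound 1 gives 1%. Compound 2 `CC(C)(C)Cc1c(-c2ccccc2)sc(N)c1C(=O)c1cccc(Cl)c1` carries the change (3-chlorophenyl in place of 4-chlorophenyl on a carbonyl carbon), and in this assay compound 2 gives 2%, a step of a number 1 percentage points higher from compound 1 to compound 2 (within the scatter). Compound 3 `COc1ccc(-c2sc(N)c(C(=O)c3ccc(Cl)cc3)c2CC(C)(C)C)cc1` differs from compound 1 by methoxy in place of hydrogen on an aromatic carbon; in this assay compound 3 gives 1%, a step of no change at the digits printed from compound 1 to compound 3 (within the scatter). Compound 4 `COc1ccc(-c2sc(N)c(C(=O)c3cccc(Cl)c3)c2CC(C)(C)C)cc1` is not yet measured; it differs from compound 3 by 3-chlorophenyl in place of 4-chlorophenyl on a carbonyl carbon, at a place that reads the same as the change from compound 1 to compound 2, so it is the same change set on the core of compound 3. From compound 3 to compound 4 the expected step is a number 1 percentage points higher from compound 3 to compound 4 (within the scatter), because the same change gave a number 1 percentage points higher from compound 1 to compound 2 (within the scatter). Compound 4 is thus estimated at 2% in this assay, between -6% and 10%.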

Compound 4, a percentage reported as inhibition, at one concentration (the size of the read-out at that concentration, not a potency): 1%
Estimate against measurement, compound 4: 1 percentage points above; low and high end bracket the measured number.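

In this assay, 3-chlorophenyl in place of 4-chlorophenyl on the carbonyl carbon gives no change at the digits printed from compound 3 to compound 4 (within the scatter), and this matches the earlier step: the same change on two cores in this assay, a number 1 percentage points higher (within the scatter) from compound 1 to compound 2 and no change at the digits printed (within the scatter) from compound 3 to compound 4, 1 percentage points apart, within the scatter of two such steps

Methoxy in place of hydrogen gives a number 1 percentage points lower from compound 2 to compound 4 (within the scatter), and this too matches the earlier step: the same change on two cores in this assay, no change at the digits printed (within the scatter) from compound 1 to compound 3 and a number 1 percentage points lower (within the scatter) from compound 2 to compound 4, 1 percentage points apart, within the scatter of two such steps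

Among the compounds shown here, with all four compounds this low in the read-out, the agreement shows only that neither change lifts inhibition on either core at the concentration tested; it does not show how a step beyond the scatter would carry from one core to another.

The compounds shown leave open whether an amine or a carboxylic acid in place of the methoxy would move the number. They also leave open what a longer chain in place of the chlorine would do.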